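This account rests on a few compounds, and the source may have more. Where it says the series, first, only, none or still open, it means among the compounds named here.

Two compounds have so far been measured in a functional assay on MV4-11 cells (Homo sapiens) for inhibition, read by luminescence and CellTiter-Glo, with a stated time of 72 h; a lower number here means a stronger inhibitor of growth, a higher number a weaker inhibitor of growth:

Compound 1, `CC(=O)N1c2ccc(-c3ccc(S(C)(=O)=O)cc3)cc2N(C(=O)c2ccco2)C[C@@H]1C` — 400 nM
Compound 2, `CC(=O)N1c2ccc(-c3ccc(S(C)(=O)=O)cc3)cc2N(C(=O)OC(C)C)C[C@@H]1C` — 350 nM

Compound 2 and compound 1 share one core and differ only in the group on the carbonyl carbon of the ring amide. The step of a 1.1-fold lower number from compound 1 to compound 2 (0.06 log units; within the scatter) lies within the scatter, so compound 2 stands level with compound 1 in this assay; neither number can be called stronger than the other.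

Compound 3, `CC(=O)N1c2ccc(-c3ccc(S(C)(=O)=O)cc3)cc2N(C(=O)C2CC2)C[C@@H]1C`, is not yet measured. It differs from compound 2 in one place: cyclopropyl in place of isopropoxy on a carbonyl carbon. Within the data shown here, the only measured step that touches this position is the one from compound 1 to compound 2, where a furan-2-yl became an isopropoxy on the same carbonyl carbon, and that step was a 1.1-fold lower number from compound 1 to compound 2 (0.06 log units; within the scatter). Two quite different groups at this carbonyl gave the same number, which points to a position that tolerates exchange. The expected step for compound 3 is therefore no change at the digits printed from compound 2 to compound 3 (within the scatter), no change beyond the scatter in either direction. On that basis compound 3 is estimated at 350 nM in this assay, with a range from 150 nM to 800 nM.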

Compound 3, concentration for 50% growth inhibition: 830 nM
Beside the measured number, compound 3's estimate is 2.4-fold (0.38 log units) below it; the whole stated range lies below it.
By their numbers in this assay, from the lowest: compounds 2 and 1 (each within the scatter of the next); then compound 3.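

In this assay, among these compounds, this carbonyl position turns out to be less indifferent than the first pair of compounds suggested: cyclopropyl gives a weaker inhibitor of growth than either isopropoxy (a 2.4-fold higher number from compound 2 to compound 3 (0.38 log units; beyond the scatter)) or furan-2-yl (a 2.1-fold higher number from compound 1 to compound 3 (0.32 log units; beyond the scatter)). Both steps are modest but beyond the scatter, so the free exchange seen between furan-2-yl and isopropoxy does not extend to every group on this carbonyl carbon, whose other neighbour is an amide-type nitrogen in a ring. No evidence at hand explains why the cyclopropyl group departs from the other two.

The compounds shown leave open whether the higher number goes with the loss of the isopropoxy oxygen or with the entry of the three-membered ring, a question that an isopropyl group on the same carbonyl carbon would help to separate. Going by these compounds, it is also open whether an amine such as dimethylamino, or a longer chain such as n-butyl, would stand level with compound 2 or move towards compound 3.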